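Working notes: from compound 2 to compound 3

The source may hold more compounds than are shown below. What is called first, only, known or untested is meant among the compounds shown, and "the series" means these compounds.

Among the compounds with values here, compound 2 `N#Cc1ccc(COc2ccc(-c3cc(CN4CCN(Cc5ccc(C(F)(F)F)cc5)CC4)no3)cc2)cc1` stands lowest of the two numbers measured so far: in a functional assay on Huh-7 cells (Homo sapiens) for antiproliferative activity, read by sulforhodamine B assay, with a stated time of 72 h (a higher number here means a weaker inhibitor, a lower number a stronger inhibitor), compound 2 gives 1000 nM. Its nearest neighbour is compound 1 `N#Cc1ccccc1COc1ccc(-c2cc(CN3CCN(Cc4ccc(C(F)(F)F)cc4)CC3)no2)cc1`, which in this assay gives 5000 nM. Within the data shown here, the only measured step, a 5.0-fold lower number from compound 1 to compound 2 (0.70 log units; beyond the scatter), came from 4-cyanophenyl in place of 2-cyanophenyl on a saturated chain carbon bound to an oxygen on an aromatic ring. Compound 3 `Fc1cccc(COc2ccc(-c3cc(CN4CCN(Cc5ccc(C(F)(F)F)cc5)CC4)no3)cc2)c1` differs from compound 2 by 3-fluorophenyl in place of 4-cyanophenyl on a saturated chain carbon bound to an oxygen on an aromatic ring. Among the measured compounds shown here, no measured step removes the nitrile or introduces fluorine; the measured step only shows that this end of the molecule shifts the number beyond the scatter, and in both directions a change here could count. Compound 3 is expected to give a somewhat higher number, estimated at 2000 nM in this assay, with a range from 700 nM to 6000 nM. The expected step is a 2.0-fold higher number from compound 2 to compound 3 (0.30 log units; within the scatter).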

Compound 3, half-maximal inhibitory concentration: 1300 nM
For compound 3 the middle estimate is 1.5-fold (0.19 log units) above the measured one, within the range that was stated.
By their numbers in this assay, from the lowest: compounds 2 and 3 (each within the scatter of the next); then compound 1.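

In this assay, the benzyl group on the oxygen tolerates this exchange: a 1.3-fold higher number from compound 2 to compound 3 (0.11 log units; within the scatter) shows that 3-fluorophenyl can stand in place of 4-cyanophenyl, so a nitrile is not needed at this position to keep the number of compound 2. With a 3.8-fold lower number from compound 1 to compound 3 (0.59 log units; beyond the scatter) as well, 2-cyanophenyl stands apart from both other groups, and among these three compounds only compound 1 lies beyond the scatter of the rest. No evidence bears on the reason for these numbers.

The exchange in compound 3 alters both the group and its ring position, so the contribution of each remains unresolved. Also open, going by these compounds, are 2-fluorophenyl and 4-fluorophenyl at this position, and whether an amine or a carboxylic acid on this ring would be tolerated.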